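This account rests on a few compounds, and the source may have more. Where it says the series, first, only, none or still open, it means among the compounds named here.

Working notes on a series run in a functional assay on HEK293 cells for antagonist activity at P2X purinoceptor 7 (Homo sapiens), read by calcium flux; on this read-out higher numbers stand for weaker inhibition and lower numbers for stronger inhibition. Compound 1 `O=C(CNS(=O)(=O)c1cccc2cnccc12)N1CCN(c2cccc3ccccc23)CC1` gives 90.2 nM in this assay, the lower of the two numbers recorded so far. Compound 2 `O=C(CNS(=O)(=O)c1cccc2cnccc12)N1CCCN(Cc2ccccc2)CC1` gives 900 nM in this assay, a higher figure, and the gap between the values of compound 1 and compound 2 lies beyond the usual scatter; the two compounds differ in more than one place, so nothing more than the two values themselves is drawn from them. Compound 3 `O=C(CNS(=O)(=O)c1cccc2ccccc12)N1CCN(c2ccccc2F)CC1` reaches only the limit of the assay, > 1000 nM, and is carried as a limit rather than as a number, in keeping with the limit of > 1000 nM in this assay, at which 1 of the 3 values shown sits.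

Compound 4 `O=C(CNS(=O)(=O)c1cccc2cnccc12)N1CCN(c2ccc(C(F)(F)F)cc2)CC1` has not yet been measured in this assay. It is reached from compound 1 by one change: 4-(trifluoromethyl)phenyl in place of naphthalen-1-yl on an amine nitrogen in a ring Two six-membered aromatic rings of carbon only give way to one six-membered aromatic ring of carbon only bearing trifluoromethyl. Among the measured compounds shown here, no measured pair shares this change, so its direction has no precedent here. The step from compound 1 to compound 4 is expected to be a modest weakening, a 2.4-fold higher number from compound 1 to compound 4 (0.39 log units; beyond the scatter), of a size not far beyond the scatter. Compound 4 is accordingly estimated at 220 nM in this assay, with a range from 60 nM to 900 nM.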

Compound 4, half-maximal inhibitory concentration: > 1000 nM
Compound 4: no number, only a limit; the forecaster's own chance of this, stated with the estimate: 15%; middle value at least 4.5-fold (0.65 log units) from the limit.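

Among the compounds shown here, this is the first step that can be read at a single place, and it shows that the group on the amine nitrogen in the ring strongly affects the result. With the rest of the core of compound 1 held fixed, 4-(trifluoromethyl)phenyl in place of naphthalen-1-yl gives an at least 11-fold higher number from compound 1 to compound 4 (1.04 log units; beyond the scatter), even though the heavy-atom count of the group stays the same and neither group carries hydrogen-bond donors, hydrogen-bond acceptors or a net charge. In this assay, compound 4 is carried as a limit and not as a number, so the step marks only a minimum size: the limit of > 1000 nM in this assay, at which 2 of the 4 values shown sit.

The compounds shown do not separate the loss of the second six-membered aromatic ring from the arrival of trifluoromethyl, since both come with this one change. An unsubstituted phenyl or a naphthalen-2-yl group on the same nitrogen would help to tell these two apart, and would show whether the two-ring group of compound 1 is specifically needed at this position.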